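Shifting Chloro from 2-Chlorophenyl to 3-Chlorophenyl

The source may report more compounds than this note shows. Statements on the series, on what has been measured and on what is new or still open speak of the compounds shown alone.

Compound 1 `Cc1ccc(S(=O)(=O)NCc2ccc(CNC(=O)c3ccc(Cl)cc3)cc2)cc1` is the reference point: in an assay on MDA-MB-231 cells for binding affinity to C-X-C chemokine receptor type 4 (Homo sapiens), read by immunofluorescence and microscopy, with stated times of 10 min and 30 min (a lower number here means that less compound is needed, a higher number that more compound is needed for the effect), compound 1 gives 10 nM. Compound 2 `Cc1ccc(S(=O)(=O)NCc2ccc(CNC(=O)c3ccccc3)cc2)cc1` carries no chloro, and for compound 2 this assay reports only a limit, > 1000 nM. Among the measured compounds shown here, the step of an at least 100-fold higher number from compound 1 to compound 2 (2.00 log units; beyond the scatter) is the only single change measured here, and it rests on (the limit of > 1000 nM in this assay, at which 1 of the 3 values shown sits), so its true size is not known beyond what that limit allows. Compound 3 `O=C(NCc1ccc(CNS(=O)(=O)c2ccccc2)cc1)c1ccccc1Cl` moves the chloro into the 2-chlorophenyl arrangement, and in this assay compound 3 gives 10 nM, level with compound 1 at the digits shown and within the usual scatter of it.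

Compound 4 `O=C(NCc1ccc(CNS(=O)(=O)c2ccccc2)cc1)c1cccc(Cl)c1` differs from compound 3 by 3-chlorophenyl in place of 2-chlorophenyl on a carbonyl carbon. The measured step from compound 1 to compound 2 concerns loss of the chloro altogether, not its relocation, so it bears on this change only indirectly: it shows that a chloro is needed, and compound 4 keeps one. For the measured compounds named here, no measured pair here shows what moving the chloro does, and compounds 1 and 3 together suggest its placement is tolerated. The step of a 1.5-fold higher number from compound 3 to compound 4 (0.18 log units; within the scatter) is therefore expected to stay within the scatter or close to it. For compound 4 in this assay the estimate is 15 nM, with a range from 5 nM to 60 nM.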

Compound 4, effective concentration (reported as EC, without a stated level of effect): 1000 nM
Compound 4: middle estimate off by 67-fold (1.82 log units), on the low side, outside the stated range (above it).
By their numbers in this assay, from the lowest: compounds 1 and 3 (each within the scatter of the next); then compound 4.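

The change keeps every atom and only rejoins the chloro on the ring attached to the carbonyl carbon, yet 3-chlorophenyl in place of 2-chlorophenyl gives a 100-fold higher number from compound 3 to compound 4 (2.00 log units; beyond the scatter) in this assay. The earlier compounds shown here showed only what losing the chloro does; this pair shows that keeping a chloro on this ring is not sufficient, and that the 2-chlorophenyl and 3-chlorophenyl arrangements are not interchangeable on the core of compound 3. Nothing in the data at hand bears on why this relocation has so large an effect.

Going by these compounds, it remains open whether the same relocation would have an effect of similar size on the core of compound 1, since this pair speaks only for the core of compound 3. On these data alone, it also remains open whether a different group in the 2-chlorophenyl arrangement, such as fluoro, bromo, methyl or methoxy in place of the chloro, would match compound 3 in this assay's read-out, or whether the chloro itself is required there.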